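Cyclohexyl for phenyl on the acyl arm of a histamine agonist

The source may report more compounds than this note shows. Statements on the series, on what has been measured and on what is new or still open speak of the compounds shown alone.

Measured compounds:
compound 1, `N=C(NCCCc1c[nH]cn1)NC(=O)CC(c1ccccc1)c1ccc(F)cc1`: 55 nM
compound 2, `N=C(NCCCc1c[nH]cn1)NC(=O)c1ccccc1`: 1170 nM

Both compounds share the same core and were tested in a functional assay on cardiac atrium for agonist activity at histamine H2 receptor (Cavia porcellus); on this read-out lower numbers stand for an effect already at smaller amounts and higher numbers for an effect only at larger amounts of compound. Compound 2, with a plain phenyl on its carbonyl carbon, gives 1170 nM, the highest number of the two. Compound 1, carrying a larger two-ring acyl group, gives 55 nM, and that gap lies well beyond the scatter.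

Compound 3, `N=C(NCCCc1c[nH]cn1)NC(=O)C1CCCCC1`, differs from compound 2 in one place: cyclohexyl in place of phenyl on a carbonyl carbon. Among the compounds with values here, no measured pair differs in exactly this way, so nothing in the data fixes the size of the step. The change keeps the number of ring atoms and leaves no donor or acceptor behind, so the step from a 1.5-fold lower number from compound 2 to compound 3 (0.17 log units; within the scatter) is expected to be small, likely within the scatter. Compound 3 is therefore expected to give about 800 nM, in the range 250 nM to 2500 nM.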

Compound 3, half-maximal effective concentration: 47.9 nM
Compound 3: middle estimate off by 17-fold (1.22 log units), on the high side, outside the stated range (below it).
By their numbers in this assay, from the lowest: compounds 3 and 1 (each within the scatter of the next); then compound 2.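

In this assay cyclohexyl in place of phenyl on a carbonyl carbon brings a 24-fold lower number from compound 2 to compound 3 (1.39 log units; beyond the scatter) and so shows that this position is highly sensitive to the change. The two groups match in their count of heavy atoms, both are six-membered rings of carbon only, and neither carries a hydrogen-bond donor or acceptor, so the one difference counted here is an aromatic ring against a non-aromatic one. No measurement available here explains the size of this step.

The compounds shown leave open whether a smaller ring such as cyclopentyl, or an open chain such as hexyl, on the same carbonyl carbon would keep a number as low as that of compound 3. They also leave open what a methylene link between the carbonyl and the cyclohexyl ring would do.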